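The source may hold more compounds than are shown below. What is called first, only, known or untested is meant among the compounds shown, and "the series" means these compounds.

Among the measured compounds shown here, in an ADME assay on MDCK cells (Canis lupus familiaris) for permeability, read by LC-MS, with a stated time of 90 min, tested at 2 uM (a lower number here means that the compound crosses the layer more slowly, a higher number that the compound crosses the layer faster), compound 1 `Cc1cc(C)c(CN2CCc3c(Cl)cc([C@H](CO)[C@H]4CCOC4)c(Cl)c3C2=O)c(=O)[nH]1` gives 2.9 10^-6 cm/s and holds the higher of the two numbers measured so far. Compound 2 `COc1cc(C)[nH]c(=O)c1CN1CCc2c(Cl)cc([C@H](O)C3COC3)c(Cl)c2C1=O` gives 0.7 10^-6 cm/s in this assay and lies lower by a gap beyond the usual scatter. These two compounds differ in more than one place, so their gap does not isolate any single change.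

The step followed here leads from compound 1 to compound 3 `Cc1cc(C)c(CN2CCc3c(Cl)cc([C@@H](C)CO)c(Cl)c3C2=O)c(=O)[nH]1`, which has not yet been measured. Compound 3 carries methyl in place of oxolan-3-yl on a saturated chain carbon bound to an aromatic carbon and a saturated chain carbon and is otherwise the same as compound 1. For the measured compounds named here, no measured pair shows this change on its own, so the expectation is a loose one. The expected change in this assay is small and upward, an estimated 1.4-fold higher number from compound 1 to compound 3 (0.14 log units; within the scatter) that may not leave the scatter. For compound 3 the estimated value is 4 10^-6 cm/s with an expected range from 1.8 10^-6 cm/s to 9 10^-6 cm/s in this assay for now.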

Compound 3, apparent permeability: 15 10^-6 cm/s
The estimate for compound 3 lay 3.8-fold (0.57 log units) below the measured number; the whole stated range lies below it.
By their numbers in this assay, from the lowest: compound 2; then compound 1; then compound 3.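

In this assay, methyl in place of oxolan-3-yl on a saturated chain carbon bound to an aromatic carbon and a saturated chain carbon gives a 5.2-fold higher number from compound 1 to compound 3 (0.71 log units; beyond the scatter), and this is the first step among these compounds that isolates a change in one place. It shows that the number responds to the group at this position, and that the smaller group gives the higher number in this one pair. The change removes a ring, a ring oxygen counted as a hydrogen-bond acceptor and a defined stereocentre all at once, and nothing measured on these compounds accounts for the step or separates these features.

The compounds shown leave open which of these features carries the step, a question that an ethyl group or a cyclopentyl ring on the same carbon would help to answer. Also open, on these data alone, is how the hydroxyl-bearing chain, which compound 1 and compound 3 share on this carbon, bears on the step, and whether the same change would give a similar step with a primary amine in place of that hydroxyl.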